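Swapping a Nitrile for a Methoxy Group on the Ring

A few compounds are considered here, and "the series" means these few. Any claim that something is new, unique, unknown or untested is made for them only; others in the source may bear on it.

Compound 1 `O=C(CCCc1ccc(C(F)(F)F)cn1)N1CCc2c(Cl)c(O)c(O)c(Cl)c2C1` gives 19%.
Compound 2 `N#Cc1ccc(CCCC(=O)N2CCc3c(Cl)c(O)c(O)c(Cl)c3C2)nc1` gives 34%.

In a functional assay (Homo sapiens), tested at 10 uM (a lower number here means a stronger effect, a higher number a weaker effect of the compound at the concentration tested), compound 2 stands highest of the two numbers, meaning the weaker effect; its nearest neighbour is compound 1, and the step of a number 15 percentage points higher from compound 1 to compound 2 (beyond the scatter) lies beyond the scatter, though it remains modest. Compound 3 `COc1ccc(CCCC(=O)N2CCc3c(Cl)c(O)c(O)c(Cl)c3C2)nc1` has not yet been measured. It differs from compound 2 in one place: methoxy in place of cyano on an aromatic carbon. Within the data shown here, only one measured step exists, and it concerns a different exchange on the same carbon, so it bears on this change only loosely: it shows that swapping the group at that place can shift the read-out by a modest amount in either direction. Among the measured compounds shown here, no measured compound carries a methoxy group, so the direction is open. A small step, possibly none beyond the scatter, is expected as a number 2 percentage points lower from compound 2 to compound 3 (within the scatter). Compound 3 is therefore expected to give about 32%, within the range 15% to 52%.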

Compound 3, a percentage reported as activity, at one concentration (the size of the read-out at that concentration, not a potency): 31%
Compound 3: the middle estimate sits 1 percentage points above what was measured; measured number inside the range.
By their numbers in this assay, from the lowest: compound 1; then compounds 3 and 2 (each within the scatter of the next).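

In this assay, putting methoxy in place of the nitrile gives a number 3 percentage points lower from compound 2 to compound 3 (within the scatter), so on this aromatic carbon these two different groups, each of two heavy atoms, cannot be told apart by this read-out. The trifluoromethyl compound stays apart from both, with a number 12 percentage points higher from compound 1 to compound 3 (beyond the scatter), so among the three groups tried here, only trifluoromethyl gives a distinct number, now against two different partners instead of one. Nothing at hand says why the groups fall out this way.

Open, on these data alone, is how an amine, a carboxylic acid or a longer alkoxy chain on this same carbon would read, and whether any would match compound 1 or go lower still. Also open, as far as these compounds go, is how a plain hydrogen there would compare, which would show how much any of these groups adds at all.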